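This account rests on a few compounds, and the source may have more. Where it says the series, first, only, none or still open, it means among the compounds named here.

Working notes on the series. Three compounds carry a number in an ADME assay on Huh-7 cells (Homo sapiens) for cytotoxicity, read by MTT assay, with a stated time of 48 h (a lower number here means that less compound is tolerated, a higher number that more compound is tolerated), so far. Compound 1 `CN(C)CCCCN(C(=O)O)c1cccc(Cn2nc(-c3ccc(F)cc3)c3ccccc3c2=O)c1` gives 8510 nM in this assay. Compound 2 `CN(C)CCCCNC(=O)Nc1ccc(CN2N=C(c3ccc(F)cc3)C3C=CC=CC3C2=O)cc1` gives 46600 nM in this assay. Compound 3 `CN(C)CCCCOC(=O)Nc1ccc(Cn2nc(-c3ccccc3)c3ccccc3c2=O)cc1` gives 16000 nM in this assay, which puts compound 3 as the second highest of the three numbers: the nearest of the other two is compound 1, at a lower number that stays within the usual scatter, and the furthest is compound 2, at a higher number that lies beyond it. Among the measured compounds shown here, no pair among the measured compounds differs in a single place, so no step of that kind is known here and none of the three gaps can be read as the effect of one change.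

Compound 4 `CN(C)CCCCOC(=O)Nc1ccc(Cn2nc(-c3cccc(C(F)(F)F)c3)c3ccccc3c2=O)cc1` is the next compound for this assay. It differs from compound 3 by trifluoromethyl in place of hydrogen on an aromatic carbon, a trifluoromethyl in place of hydrogen on an aromatic carbon. The measured compounds offer no comparison for this change. The step of a 1.3-fold lower number from compound 3 to compound 4 (0.12 log units; within the scatter) is expected to be small, with no direction that clearly exceeds the scatter. Compound 4 is accordingly estimated at 12000 nM, within a range from 5000 nM to 30000 nM.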

Compound 4, half-maximal cytotoxic concentration: 11600 nM
Beside the measured number, compound 4's estimate is 1.0-fold (0.01 log units) above it; low and high end bracket the measured number.
By their numbers in this assay, from the lowest: compounds 1, 4 and 3 (each within the scatter of the next); then compound 2.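

Among the compounds shown here, the pair of compound 3 and compound 4 gives the first single-place comparison. In this assay, trifluoromethyl in place of hydrogen on an aromatic carbon, which turns phenyl into 3-(trifluoromethyl)phenyl, gives a 1.4-fold lower number from compound 3 to compound 4 (0.14 log units; within the scatter). At this place on the six-membered aromatic ring of carbon only, four heavy atoms can therefore enter in place of a hydrogen atom with no change beyond the usual scatter, although this is a single pair and sets no pattern, and no accompanying measurement speaks to the origin of this result.

Going by these compounds, whether the same holds for other groups at this place, such as a chlorine atom, a methoxy group, a nitrile or a carboxylic acid, stays open, as does whether trifluoromethyl behaves alike on another carbon of this ring. Also open, on these data alone, is whether the step carries over to the different frameworks of compound 1 and compound 2, since neither forms a single-place pair with compound 3 or compound 4.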